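This account rests on a few compounds, and the source may have more. Where it says the series, first, only, none or still open, it means among the compounds named here.

Working notes on the series. Of the compounds shown here, three have been measured: compound 1 `CN1C[C@H]2C=C(c3cccnc3)C[C@H](C2)C1`, compound 2 `C1=C(c2cccnc2)C[C@@H]2CNC[C@H]1C2` and compound 3 `C1=C(c2cncc(Oc3ccccc3)c2)CC2CNCC1C2`. In an in vitro functional assay on SH-EP1 cells for agonist activity at Neuronal acetylcholine receptor; alpha4/beta2 (Homo sapiens), read by voltage clamp (a lower number here means a smaller maximal response, a higher number a larger maximal response), compound 1 gives 19%, compound 2 gives 32% and compound 3 gives 9%. On these numbers compound 3 sits beyond the scatter below compound 2, while its gap to compound 1 falls within the scatter, so no order between compound 3 and compound 1 can be read from the data. Within the data shown here, no pair of measured compounds differs in a single place, so the series contains no measured step of any kind.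

The next compound, compound 4 `CC(C)Oc1cncc(C2=CC3CNCC(C2)C3)c1`, differs from compound 3 in one place: isopropyl in place of phenyl on an oxygen on an aromatic ring. Among the measured compounds shown here, nothing measured so far pairs a phenoxy with an isopropoxy, so the size and direction of this change are not known from the series; the working expectation is that the step in this assay from compound 3 to compound 4 stays within the scatter, with a slight lean downward because compound 3 already gives 9% and the numbers in this assay cluster low. Expected step: no change at the digits printed from compound 3 to compound 4 (within the scatter). Compound 4 is accordingly estimated at 9%, within a range from 2% to 25%.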

Compound 4, largest response reached (reported as percent of maximum), in percent of the reference or control that the assay uses: 11%
Compound 4: middle estimate off by 2 percentage points, on the low side, within the range that was stated.
By their numbers in this assay, from the lowest: compounds 3, 4 and 1 (each within the scatter of the next); then compound 2.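

In this assay the series now has its first measured step, a number 2 percentage points higher from compound 3 to compound 4 (within the scatter), for isopropyl in place of phenyl on an oxygen on an aromatic ring. At this position, then, a group with no ring and 3 heavy atoms reads the same, within the scatter, as an aromatic ring with 6 heavy atoms, so this one exchange gives no sign that the response depends on the aromatic ring of the phenoxy. No measurement at hand explains this outcome.

Going by these compounds, it remains open whether any group on this oxygen can move the response beyond the scatter, since a phenoxy and an isopropoxy are only two cases: a methyl, a cyclopropyl, a longer chain such as n-butyl or a chain ending in an amine would test that. The part played by the oxygen itself is also unresolved, and a sulfur or a methylene in its place, with the isopropyl kept, would address it.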